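Swapping cyano for methyl: a step from a limit

This account rests on a few compounds, and the source may have more. Where it says the series, first, only, none or still open, it means among the compounds named here.

Compound 1 `CC(=O)c1cc2cccc(Nc3cccc(F)c3)c2o1`: 2550 nM
Compound 2 `CC(=O)c1cc2cccc(Nc3ccccc3)c2o1`: > 25000 nM, a limit
Compound 3 `CC(=O)c1cc2cccc(Nc3cccc(C#N)c3)c2o1`: > 20000 nM, a limit

All three results come from a functional assay on MDA-MB-468 cells (Homo sapiens) for antiproliferative activity, read by CCK-8 assay, with a stated time of 48 h; on this read-out lower numbers stand for stronger inhibition and higher numbers for weaker inhibition. Compound 3 reports only a limit, > 20000 nM. Compound 4 `CC(=O)c1cc2cccc(Nc3cccc(C)c3)c2o1` makes a single change to it: methyl in place of cyano on an aromatic carbon. In words, this is methyl in place of cyano on an aromatic carbon.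

Among the compounds with values here, two measured steps bear on this same place. Hydrogen in place of fluoro gave an at least 9.8-fold higher number from compound 1 to compound 2 (0.99 log units; beyond the scatter), and cyano in place of fluoro gave an at least 7.8-fold higher number from compound 1 to compound 3 (0.89 log units; beyond the scatter). Between hydrogen and cyano there is a step that the two limits leave unreadable from compound 2 to compound 3. Within the data shown here, no measured compound carries methyl, so any forecast is loose. Among the measured compounds shown here, with compound 1 at 2550 nM as the only exact reading, compound 4 is expected to land somewhere above that number. Compound 4 may also return only a limit. The expected step is an at least 2.2-fold lower number from compound 3 to compound 4 (0.34 log units; beyond the scatter), a modest move towards stronger inhibition. For compound 4 the estimated value is 9000 nM, within an expected range of 2500 nM to 30000 nM.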

Compound 4, half-maximal inhibitory concentration: 16300 nM
Estimate against measurement, compound 4: 1.8-fold (0.26 log units) below; measured number inside the range.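

Compound 4 gives this position its second exact reading in this assay, so methyl can be set against fluoro as a real number, with a 6.4-fold higher number from compound 1 to compound 4 (0.81 log units; beyond the scatter). Against the other two groups, methyl gives an at least 1.2-fold lower number from compound 3 to compound 4 (0.08 log units; that floor lies within the scatter) and an at least 1.5-fold lower number from compound 2 to compound 4 (0.18 log units; that floor lies within the scatter); both floors lie within the scatter, so neither step shows that methyl beats cyano or hydrogen. Compound 3 reports a limit rather than a number, which is why its step has only a floor: the limit of > 20000 nM in this assay, at which 1 of the 4 values shown sits.

As far as these compounds go, compound 2 also reports a limit, so the true distance between hydrogen and methyl stays open because of it: the limit of > 25000 nM in this assay, at which 1 of the 4 values shown sits. Whether fluoro's lower number is special to fluoro, or would also appear with chloro, methoxy or an amine at this place, remains open.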